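Diaryl ether dopamine transporter series: sultam to amide swap

The compounds below may be only part of what the source reports. "The series", "measured", "known", "first", "only" and "open" are said of these compounds alone.

Measured so far:
compound 1 `CN(C)Cc1ccccc1Oc1ccccc1` — "not determined" (no result reported)
compound 2 `CNCc1cc(N2CCCS2(=O)=O)ccc1Oc1ccc(Cl)cc1Cl` — 138 nM

Going by the values given here, compound 2 `CNCc1cc(N2CCCS2(=O)=O)ccc1Oc1ccc(Cl)cc1Cl` is the only member of the series with a number: in an assay on HEK293 cells for inhibition of sodium-dependent dopamine transporter (Homo sapiens) (on this read-out lower numbers stand for stronger inhibition and higher numbers for weaker inhibition), compound 2 gives 138 nM. Among the compounds with values here, compound 1 `CN(C)Cc1ccccc1Oc1ccccc1` is part of the set, but in this assay compound 1 gives "not determined" (no result reported), so no comparison within measured compounds is possible and no step between measured compounds is known.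

Compound 3 `CNCc1cc(C(=O)N(C)C)ccc1Oc1ccc(Cl)cc1Cl` is the next entry. It differs from compound 2 in one place: a group of 5 heavy atoms (3 carbon, 1 nitrogen, 1 oxygen; no ring) in place of a group of 7 heavy atoms (3 carbon, 1 nitrogen, 2 oxygen, 1 sulfur; one five-membered non-aromatic ring with 2 hetero atoms), on an aromatic carbon. The dimethylcarbamoyl enters where the five-membered non-aromatic ring with 2 hetero atoms leaves, on an aromatic carbon.

Within the data shown here, with no reference step, the change is expected to stay within the usual scatter: the step of a 1.2-fold higher number from compound 2 to compound 3 (0.06 log units; within the scatter) is estimated as small, in no firm direction. Compound 3 is expected to give about 160 nM in this assay, with a range of 55 nM to 480 nM.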

Compound 3, half-maximal inhibitory concentration: 275 nM
Compound 3: middle estimate off by 1.7-fold (0.24 log units), on the low side, and the stated range covers the measured number.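

In this assay, going by these compounds alone, the step of a 2.0-fold higher number from compound 2 to compound 3 (0.30 log units; within the scatter) is the first readable one and concerns the aromatic carbon meta to the (methylamino)methyl group. At this position, the dimethylcarbamoyl, with no ring and 1 hydrogen-bond acceptor, takes the place of the five-membered non-aromatic ring with 2 hetero atoms, and the step stays within the scatter, so that ring is not needed here for a number of this size. No measurement shown offers an explanation for this outcome, and the single step assigns no effect to either group.

Still open, on these data alone, is whether a carboxylic acid, a primary amide or an open-chain sulfonamide at this position would stay in the same range. Also open, as far as these compounds go, is how an amine or a longer alkyl chain at this position would read out.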